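The source may report more compounds than this note shows. Statements on the series, on what has been measured and on what is new or still open speak of the compounds shown alone.

In a functional assay on MDA-MB-231 cells (Homo sapiens) for antiproliferative activity, read by MTT assay, with a stated time of 72 h (on this read-out higher numbers stand for weaker inhibition and lower numbers for stronger inhibition), compound 1 `O=C(O)CCCCCOc1ccc2cc1COC/C=C/COCc1cccc(c1)-c1ccnc(n1)N2` gives 19900 nM. Compound 2 `O=C(NO)c1cccc(NCCOc2ccc3cc2COC/C=C/COCc2cccc(c2)-c2ccnc(n2)N3)c1` gives > 50000 nM, which is a limit of the assay and not a number. Of the pair, only compound 2 sits at that limit, as this record shows: the limit of > 50000 nM in this assay, at which 1 of the 2 values shown sits.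

Compound 3 `O=C(O)CCCCCCCOc1ccc2cc1COC/C=C/COCc1cccc(c1)-c1ccnc(n1)N2` is still unmeasured. It differs from compound 2 as follows: 5-carboxypentyl in place of (3-(hydroxycarbamoyl)phenyl)amino on a saturated chain carbon, two bonds along the chain from an oxygen on an aromatic ring. In words, it has 5-carboxypentyl in place of (3-(hydroxycarbamoyl)phenyl)amino on a saturated chain carbon, two bonds along the chain from an oxygen on an aromatic ring.

Among the measured compounds shown here, one measured step bears on this change: an at least 2.5-fold higher number from compound 1 to compound 2 (0.40 log units; beyond the scatter). That step went from a carboxylic acid chain to the group that compound 3 now gives up, and compound 3 returns to an acid chain, though a 5-carboxypentyl rather than a 3-carboxypropyl one. A modest move to a lower number in this assay is therefore expected, landing near compound 1 at 19900 nM. The expected change is an at least 3.3-fold lower number from compound 2 to compound 3 (0.52 log units; beyond the scatter). For compound 3 the estimated value is 15000 nM, with an expected range from 6000 nM to 40000 nM.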

Compound 3, half-maximal inhibitory concentration: 17100 nM
Beside the measured number, compound 3's estimate is 1.1-fold (0.06 log units) below it; the range from low to high includes it.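

Putting 5-carboxypentyl in place of (3-(hydroxycarbamoyl)phenyl)amino, on a saturated chain carbon, two bonds along the chain from an oxygen on an aromatic ring, gives an at least 2.9-fold lower number from compound 2 to compound 3 (0.46 log units; beyond the scatter) in this assay, so a second acid chain now stands on the stronger side of that group, as the first one did. The figure for compound 2 is a limit of the assay and not a number, so this step has a floor but no true size: the limit of > 50000 nM in this assay, at which 1 of the 3 values shown sits. The two acid chains themselves cannot be told apart, since 2-carboxyethyl in place of carboxy on a saturated chain carbon, five bonds along the chain from an oxygen on an aromatic ring, gives a 1.2-fold lower number from compound 1 to compound 3 (0.07 log units; within the scatter), and within this pair the added chain length shows no effect on the read-out.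

The compounds shown leave open which part of the (3-(hydroxycarbamoyl)phenyl)amino group goes with the weaker inhibition, the hydroxycarbamoyl end or the aromatic ring with its amine, as both leave together in this change. They also leave open how a much shorter acid chain, or a hydroxycarbamoyl group at the end of a plain saturated chain, would read in this assay.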